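This account rests on a few compounds, and the source may have more. Where it says the series, first, only, none or still open, it means among the compounds named here.

Working notes on a small urea series followed in an ADME assay on the whole organism with Oryza sativa as the target, tested at 0.1 uM; a lower number here means a stronger effect, a higher number a weaker effect of the compound at the concentration tested.

Compound 1 `CCOC(=O)c1cccc(NC(=O)N[C@@H](C)c2ccccc2)c1` gives 100% in this assay. Compound 2 `CCOC(=O)c1ccc(NC(=O)N[C@H](C)c2ccccc2)cc1` is built from the same atoms as compound 1, joined differently; the difference between the two cores is not broken down here. In this assay compound 2 gives 101%, which lies within the scatter of the value of compound 1. Compound 3 `CC(=O)c1cccc(NC(=O)N[C@@H](C)c2ccccc2)c1` differs from compound 1 by methyl in place of ethoxy on a carbonyl carbon. In this assay compound 3 gives 96%. The step of a number 4 percentage points lower from compound 1 to compound 3 (within the scatter) shows that this change leaves the read-out essentially where it was. The values of compound 3 and compound 2 also lie within the scatter of each other, so no order among the three is claimed.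

Compound 4 `CC(=O)c1ccc(NC(=O)N[C@H](C)c2ccccc2)cc1` has not yet been measured. It differs from compound 2 by methyl in place of ethoxy on a carbonyl carbon, the same change as that carried out between compound 1 and compound 3, here made on the core of compound 2 instead of the core of compound 1; the surroundings of the place are described in identical words. Among the four compounds this change occurs twice in all.

The expectation for compound 4 rests on a single earlier instance, a number 4 percentage points lower from compound 1 to compound 3 (within the scatter), which lies within the scatter. The expected step is a number 4 percentage points lower from compound 2 to compound 4 (within the scatter), of similar size, because a number 4 percentage points lower from compound 1 to compound 3 (within the scatter) gave no meaningful movement. Compound 4 is therefore estimated at 97% in this assay, with a range from 87% to 107%.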

Compound 4, a percentage reported as activity, at one concentration (the size of the read-out at that concentration, not a potency): 96%
Beside the measured number, compound 4's estimate is 1 percentage points above it; measured number inside the range.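

In this assay, methyl in place of ethoxy on a carbonyl carbon gives a number 5 percentage points lower from compound 2 to compound 4 (within the scatter), so on this core too the change leaves the read-out essentially where it was. Set beside the earlier instance, the same change reads alike on the two cores: the same change on two cores in this assay, a number 4 percentage points lower (within the scatter) from compound 1 to compound 3 and a number 5 percentage points lower (within the scatter) from compound 2 to compound 4, 1 percentage points apart, within the scatter of two such steps. This shows that, for these two cores, the ethoxycarbonyl to acetyl change carries over as a change without meaningful movement; as neither step leaves the scatter, it does not show that a step of real size would carry over in the same way, and two instances give no rule for the wider series.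

The compounds shown leave open whether any other group on this carbonyl carbon, such as an amine giving an amide, a hydroxyl giving a carboxylic acid, or a longer chain such as propoxy, would move the read-out in this assay. They also leave open whether the read-out responds to changes elsewhere in the molecule, for example a substituent such as chlorine on the ring of the phenylethyl part, since all the steps shown concern this one place.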